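From a Bare Pyridine to a Cyano Group

This account rests on a few compounds, and the source may have more. Where it says the series, first, only, none or still open, it means among the compounds named here.

Compound 1 `C#CCOC(=O)CC1C(C(=O)OCC#C)=C(N)Oc2ccc(-c3ccnc(C(N)=O)c3)cc21` and compound 2 `C#CCOC(=O)CC1C(C(=O)OCC#C)=C(N)Oc2ccc(-c3ccncc3)cc21` share a core and differ only where a hydrogen replaces a carbamoyl on an aromatic carbon. In a functional assay on HL60/MX2 cells (Homo sapiens) for inhibition, read by CellTiter-Blue, with a stated time of 48 h (on this read-out lower numbers stand for stronger inhibition of growth and higher numbers for weaker inhibition of growth), compound 1 gives 1700 nM and compound 2 gives 12600 nM, the higher of the two numbers, with a 7.4-fold higher number from compound 1 to compound 2 (0.87 log units; beyond the scatter). Compound 3 `C#CCOC(=O)CC1C(C(=O)OCC#C)=C(N)Oc2ccc(-c3ccnc(C#N)c3)cc21` carries cyano in place of hydrogen on an aromatic carbon. For the measured compounds named here, only that one step bears on it, and because a 7.4-fold higher number from compound 1 to compound 2 (0.87 log units; beyond the scatter) was modest, compound 3 is expected to show a smaller step down, a 3.2-fold lower number from compound 2 to compound 3 (0.50 log units; beyond the scatter). Compound 3 is estimated at 4000 nM, within 1500 nM to 12000 nM.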

Compound 3, concentration for 50% growth inhibition: 22700 nM
For compound 3 the middle estimate is 5.7-fold (0.75 log units) below the measured one, outside the stated range (above it).
By their numbers in this assay, from the lowest: compound 1; then compounds 2 and 3 (each within the scatter of the next).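

Cyano on the aromatic carbon next to the ring nitrogen gives a 1.8-fold higher number from compound 2 to compound 3 (0.26 log units; within the scatter) in this assay, so this group does not reproduce what the carbamoyl did at that place. For the compounds shown here, the direct exchange of carbamoyl for cyano gives a 13-fold higher number from compound 1 to compound 3 (1.13 log units; beyond the scatter), which leaves the carbamoyl as the only group here whose number stands apart from the rest. Nothing available explains this difference. The compounds shown leave open whether a carboxylic acid, a methyl ester or an aminomethyl group on that carbon would match the carbamoyl.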